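A methyl group shifts place in compound 2

A few compounds are considered here, and "the series" means these few. Any claim that something is new, unique, unknown or untested is made for them only; others in the source may bear on it.

Of the compounds shown here, two built on the shared core have been measured so far, compound 1 (`CCC(CC)[C@@H]1C(=O)N[C@H](C2Cc3ccccc3C2)C(=O)N1[C@@H](C(=O)N1CCOCC1)c1ccc(C)nc1`) and compound 2 (`CC[C@H](C)[C@@H]1C(=O)N[C@H](C2Cc3ccccc3C2)C(=O)N1[C@@H](C(=O)N(C)C)c1ccc(C)nc1C`). In an in vitro ADME assay on microsomes from liver (Macaca fascicularis) for metabolic stability (a lower number here means slower removal, a higher number faster removal of the compound), compound 1 gives 18 mL.min-1.g-1. In this assay compound 2 gives 14 mL.min-1.g-1. These two numbers lie within the usual scatter of repeated measurements, so compound 2 stands level with compound 1 and no ranking can be read from them.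

Compound 3 (`CC[C@H](C)[C@@H]1C(=O)N[C@H](C2Cc3ccccc3C2)C(=O)N1[C@@H](C(=O)N(C)C)c1cc(C)cnc1C`) has not been measured yet. It has the same atoms as compound 2, joined differently: 2,5-dimethylpyridin-3-yl in place of 2,6-dimethylpyridin-3-yl on a saturated chain carbon bound to an amide-type nitrogen in a ring and a carbonyl carbon. The 2,5-dimethylpyridin-3-yl group thus takes the place of the 2,6-dimethylpyridin-3-yl group, and the rest of the molecule stays as it was.

For the measured compounds named here, no measured pair here shows what a change of this kind does, so no direction can be argued with confidence, and no shift beyond the scatter is expected in this assay. The expected step of a 1.1-fold higher number from compound 2 to compound 3 (0.06 log units; within the scatter) is therefore small. Compound 3 is expected to give about 16 mL.min-1.g-1, with an estimated range of 8 mL.min-1.g-1 to 30 mL.min-1.g-1.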

Compound 3, intrinsic clearance in microsomes: 13 mL.min-1.g-1
The estimate for compound 3 lay 1.2-fold (0.09 log units) above the measured number, and the stated range covers the measured number.
By their numbers in this assay, from the lowest: compounds 3, 2 and 1 (each within the scatter of the next).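

In this assay, putting the 2,5-dimethylpyridin-3-yl group in place of the 2,6-dimethylpyridin-3-yl group gives a 1.1-fold lower number from compound 2 to compound 3 (0.03 log units; within the scatter), so compound 2 and compound 3 stand level. For the compounds shown here, this is the first pair here that differs in one place, and it gives a direct reading that the earlier comparison of compound 1 and compound 2 could not give: on this saturated chain carbon, this rearrangement of the same atoms produces no shift that can be told from the scatter in this assay. No measurement of any other property of these compounds is available to account for this result.

The compounds shown leave open what happens when something other than a methyl group sits on this six-membered aromatic ring, for example an amine, a methoxy group or a carboxylic acid, or when a longer chain such as propyl replaces one of the methyl groups. They also leave open whether the same exchange would read the same way on a compound that differs elsewhere, since one pair sets no general pattern.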